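The compounds below may be only part of what the source reports. "The series", "measured", "known", "first", "only" and "open" are said of these compounds alone.

Three measured compounds share one core and differ in the group hanging from the outer benzene ring. Compound 1 `Cn1nc2c(=O)n(CC3(O)CCN(Cc4ccc(-c5ccco5)cc4Cl)CC3)cnc2c1-c1ccc(CO)cc1` carries a hydroxymethyl group there and in an assay on isolated protein for inhibition of ubiquitin carboxyl-terminal hydrolase 7 (Homo sapiens), with stated times of 30 min and 2 h (on this read-out lower numbers stand for stronger inhibition and higher numbers for weaker inhibition), compound 1 gives 42.5 nM. Compound 2 `Cn1nc2c(=O)n(CC3(O)CCN(Cc4ccc(-c5ccco5)cc4Cl)CC3)cnc2c1-c1ccc(C2(N)CC2)cc1` carries a 1-aminocyclopropyl group instead, and in this assay compound 2 gives 66.1 nM; the step of a 1.6-fold higher number from compound 1 to compound 2 (0.19 log units; within the scatter) is small. Compound 3 `Cn1nc2c(=O)n(CC3(O)CCN(Cc4ccc(-c5ccoc5)cc4Cl)CC3)cnc2c1-c1ccc(CN)cc1` carries an aminomethyl group, and in this assay compound 3 gives 177 nM. Among these three numbers, compound 2 stands second highest: close to compound 1 and further from compound 3.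

Compound 4 `Cn1nc2c(=O)n(CC3(O)CCN(Cc4ccc(-c5ccco5)cc4Cl)CC3)cnc2c1-c1ccc(CNCCO)cc1` is not yet measured. It differs from compound 2 by ((2-hydroxyethyl)amino)methyl in place of 1-aminocyclopropyl on an aromatic carbon. For the measured compounds named here, only the step from compound 1 to compound 2 bears on this position, and it stayed within the scatter, so the numbers here seem to move little when this group changes. The new group, however, is open-chain rather than ring-shaped, and compound 3 with its aminomethyl group gives the highest number of the three, which leaves some room for a weaker result. A modest rise, a 1.5-fold higher number from compound 2 to compound 4 (0.18 log units; within the scatter), is therefore expected for compound 4. Compound 4 is estimated at 100 nM, with a likely range from 40 nM to 250 nM.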

Compound 4, half-maximal inhibitory concentration: 8.2 nM
Compound 4: the middle estimate sits 12-fold (1.09 log units) above what was measured, and the stated range ends above it.
By their numbers in this assay, from the lowest: compound 4; then compounds 1 and 2 (each within the scatter of the next); then compound 3.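

In this assay, this position proves far more sensitive than the first step suggested: the ((2-hydroxyethyl)amino)methyl group gives an 8.1-fold lower number from compound 2 to compound 4 (0.91 log units; beyond the scatter), and the same group also gives a 5.2-fold lower number from compound 1 to compound 4 (0.71 log units; beyond the scatter). Compound 4 thus shows that an open chain without a ring can be accommodated here, and that a group holding both an amine nitrogen, as in compound 2, and a hydroxyl, as in compound 1, can outperform either of those simpler groups. Nothing available explains this gain.

On these data alone, it remains open what an ethylamino chain lacking the hydroxyl would give, and so whether the hydroxyl contributes to the gain at all. As far as these compounds go, a longer 3-hydroxypropylamino chain, or a carboxylic acid at the chain end, is equally open.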